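The source may hold more compounds than are shown below. What is called first, only, known or untested is meant among the compounds shown, and "the series" means these compounds.

Compound 1 `COc1cc(C=C(C(=O)/C=C/c2cccc(OC)c2OC)C(=O)/C=C/c2cccc(OC)c2OC)cc(OC)c1O` and compound 2 `COc1ccc(C=C(C(=O)/C=C/c2cccc(OC)c2OC)C(=O)/C=C/c2cccc(OC)c2OC)cc1O` are built on one shared core, while compound 3 `COc1ccc(/C=C/C(=O)C(=Cc2cc(OC)c(O)c(OC)c2)C(=O)/C=C/c2ccc(OC)cc2OC)c(OC)c1` and the as yet unmeasured compound 4 `COc1ccc(/C=C/C(=O)C(=Cc2ccc(OC)c(O)c2)C(=O)/C=C/c2ccc(OC)cc2OC)c(OC)c1` are built on another; the difference between the two cores is not broken down here. In a functional assay on MCF7 cells (Homo sapiens) for antiproliferative activity, read by sulforhodamine B assay, with a stated time of 48 h (on this read-out lower numbers stand for stronger inhibition and higher numbers for weaker inhibition), compound 1 gives 460 nM. In this assay compound 2 gives 310 nM. The structural change that separates the two is 3-hydroxy-4-methoxyphenyl in place of 4-hydroxy-3,5-dimethoxyphenyl on a double-bonded chain carbon bound to a double-bonded chain carbon, and it produced a 1.5-fold lower number from compound 1 to compound 2 (0.17 log units; within the scatter), so the two numbers cannot be told apart with confidence. In this assay compound 3 gives 970 nM, the highest number among the three measured compounds, standing beyond the scatter from both compound 1 and compound 2.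

Compound 4 is related to compound 3 by the same change that relates compound 2 to compound 1: 3-hydroxy-4-methoxyphenyl in place of 4-hydroxy-3,5-dimethoxyphenyl on a double-bonded chain carbon bound to a double-bonded chain carbon. This change has been seen once so far, and it left the read-out essentially unchanged. Among the compounds with values here, on that basis the step from compound 3 to compound 4 in this assay is expected to be small, about a 1.5-fold lower number from compound 3 to compound 4 (0.17 log units; within the scatter), set beside the earlier step because a 1.5-fold lower number from compound 1 to compound 2 (0.17 log units; within the scatter) is the only precedent in hand. Within the data shown here, compound 4 is therefore estimated to give 650 nM in this assay, with the likely range running from 330 nM to 1300 nM, the width reflecting that a single prior step on a different core is the only guide.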

Compound 4, half-maximal inhibitory concentration: 1600 nM
Compound 4: middle estimate off by 2.5-fold (0.39 log units), on the low side; measured number outside the range, above it.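

In this assay, putting 3-hydroxy-4-methoxyphenyl in place of 4-hydroxy-3,5-dimethoxyphenyl on the second core gave a 1.6-fold higher number from compound 3 to compound 4 (0.22 log units; within the scatter), so here too the change leaves two numbers that cannot be told apart with confidence. Set beside the earlier step, this one does not differ from it, and in this series the change has so far stayed small on both cores: the same change on two cores in this assay, a 1.5-fold lower number (0.17 log units; within the scatter) from compound 1 to compound 2 and a 1.6-fold higher number (0.22 log units; within the scatter) from compound 3 to compound 4, 2.4-fold (0.39 log units) apart, within the scatter of two such steps This does not show that the change has a fixed direction or size that carries from core to core, since the two steps point opposite ways but each is a single pair within the scatter, and two cores are too few to establish a rule for the series.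

The compounds shown exchange only these two hydroxylated, methoxylated phenyl groups on a double-bonded chain carbon bound to a double-bonded chain carbon, so they leave open whether any replacement at that place can move the number beyond the scatter on either core. As far as these compounds go, whether a phenyl group carrying an amine or a carboxylic acid there would do so remains unknown, as does how the present change would behave on a third core.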